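Removing a Methoxy Group on a Brominated Core

A few compounds are considered here, and "the series" means these few. Any claim that something is new, unique, unknown or untested is made for them only; others in the source may bear on it.

Compound 1 `COc1ccc(NCc2nc3ccccc3[nH]2)cc1` and compound 2 `c1ccc(NCc2nc3ccccc3[nH]2)cc1` share one core, while compound 3 `COc1ccc(NCc2nc3ccc(Br)cc3[nH]2)cc1` carries a changed core. In a functional assay on the whole organism (strain albino) for inhibition, with Rattus norvegicus as the target, read by paw edema, with a stated time of 180 min, at a dose of 100 mg/kg by the oral route (a lower number here means less inhibition, a higher number more inhibition at the dose given (going by the name of the read-out)), compound 1 gives 33.3%, compound 2 gives 38.8%, and compound 3 gives 12.5%. The change from compound 1 to compound 2 is hydrogen in place of methoxy on an aromatic carbon, and it made a step of a number 5.5 percentage points higher from compound 1 to compound 2 (within the scatter). The two cores differ by bromo in place of hydrogen on an aromatic carbon, which made a step of a number 20.8 percentage points lower from compound 1 to compound 3 (beyond the scatter). Compound 4 `Brc1ccc2nc(CNc3ccccc3)[nH]c2c1` has not yet been measured in this assay. It differs from compound 3 by hydrogen in place of methoxy on an aromatic carbon, the same change as from compound 1 to compound 2. Because the earlier step of a number 5.5 percentage points higher from compound 1 to compound 2 (within the scatter) lay within the scatter, a step of similar size is expected from compound 3 to compound 4, estimated as a number 5.5 percentage points higher from compound 3 to compound 4 (within the scatter). Compound 4 is therefore expected to give 18% in this assay, estimated between 8% and 30%.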

Compound 4, a percentage reported as inhibition, in the whole organism at one dose (the size of the read-out at that dose, not a potency): 22.2%
Compound 4: the middle estimate sits 4.2 percentage points below what was measured; low and high end bracket the measured number.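

In this assay, hydrogen in place of methoxy on the brominated core gave a number 9.7 percentage points higher from compound 3 to compound 4 (within the scatter), which matches the same change on the core without bromo: the same change on two cores in this assay, a number 5.5 percentage points higher (within the scatter) from compound 1 to compound 2 and a number 9.7 percentage points higher (within the scatter) from compound 3 to compound 4, 4.2 percentage points apart, within the scatter of two such steps. Bromo in place of hydrogen, with no methoxy present, gave a number 16.6 percentage points lower from compound 2 to compound 4 (beyond the scatter), and this matches the earlier bromo step: the same change on two cores in this assay, a number 20.8 percentage points lower (beyond the scatter) from compound 1 to compound 3 and a number 16.6 percentage points lower (beyond the scatter) from compound 2 to compound 4, 4.2 percentage points apart, within the scatter of two such steps. Across these four compounds, both changes carry over from one core to the other, but the methoxy step lies within the scatter on both cores, so it cannot be told apart from no change, and two cores do not make a rule for the whole series.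

The compounds shown leave open whether another group in the methoxy position, such as an amine or a carboxylic acid, would carry over in the same way. They also leave open whether chloro in place of bromo would lower the number as bromo does.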